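The source may hold more compounds than are shown below. What is called first, only, known or untested is meant among the compounds shown, and "the series" means these compounds.

The measured compounds and their values come first.

Compound 2 `Cc1ccc(S(=O)(=O)Oc2ccc3c(c2C)[C@H](Cn2cc(-c4ccccn4)nn2)[C@@]24CC(=O)[C@@](C)(CC[C@@H]32)C4)cc1`: in a functional assay on HL-60 cells (Homo sapiens) for cytotoxicity, read by MTT assay, with a stated time of 4 days (on this read-out lower numbers stand for stronger inhibition and higher numbers for weaker inhibition), compound 2 gives > 20000 nM, which is a limit of the assay and not a number.
Compound 3 `Cc1c(O)ccc2c1[C@H](Cn1cc(-c3ccccn3)nn1)[C@@]13CC(=O)[C@@](C)(CC[C@@H]21)C3`: compound 3 gives > 20000 nM, likewise a limit.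
Compound 1 `C=C1C(=O)[C@]23C[C@@]1(O)CC[C@H]2c1ccc(OS(=O)(=O)c2ccc(C)cc2)c(C)c1[C@@H]3Cn1cc(-c2ccccn2)nn1`: compound 1 gives 1810 nM.

Compound 2 therefore stands at the limit of > 20000 nM in this assay, at which 2 of the 3 values shown sit; no number is known for it. Among the measured compounds shown here, the one step recorded between measured compounds, a step that the two limits leave unreadable from compound 2 to compound 3, runs from one limit to another and gives no readable size. Compound 1 differs from compound 2 in more than one place, so the two values only show that compound 1 returns a number while compound 2 returns a limit.

Compound 4 `Cc1ccc(-c2cn(C[C@H]3c4c(ccc(OS(=O)(=O)c5ccc(C)cc5)c4C)[C@@H]4CC[C@@]5(C)C[C@]43CC5=O)nn2)cc1` differs from compound 2 by 4-methylphenyl in place of pyridin-2-yl on an aromatic carbon. For the measured compounds named here, none of the measured steps touches this part of the molecule, so no measured step bears on the change, and there is no ground to expect a move in this assay in either direction beyond the scatter. Starting from a limit, the estimate for compound 4 is 20000 nM, with a range from 5000 nM to 60000 nM. The step from compound 2 to compound 4 is accordingly expected to be a number no higher from compound 2 to compound 4 (the limit leaves the size open), and a further limit is the most likely outcome.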

Compound 4, half-maximal inhibitory concentration: > 20000 nM
Compound 4: no number, only a limit; the forecaster's own chance of this, stated with the estimate: 70%; the middle value sits exactly at the limit.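

In this assay compound 4 gives > 20000 nM, which is a limit of the assay and not a number. Compound 2 also stands at a limit, and no step can be read between compound 2 and compound 4. The compounds shown leave open what numbers these two compounds would give, and whether 4-methylphenyl in place of pyridin-2-yl changes the value at all.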